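The source may hold more compounds than are shown below. What is called first, only, known or untested is meant among the compounds shown, and "the series" means these compounds.

Measured compounds:
- compound 1, `COCC1=C(C(=O)OC)C(c2cc(F)c(F)cc2F)N(C(=O)NCCCN2CCN(c3ccccc3C(N)=O)CC2)C(=O)N1`, 190 nM in an assay on liver for binding affinity to Alpha-1D adrenergic receptor (Homo sapiens), using microsomes; a lower number here means a stronger inhibitor, a higher number a weaker inhibitor
- compound 2, `CCOc1ccccc1N1CCN(CCCNC(=O)N2C(=O)NC(C)=C(C(=O)OC)C2c2ccc(F)c(F)c2)CC1`, 14 nM in this assay

Compound 2 has the lowest number of the two in this assay; its nearest neighbour is compound 1, whose number is higher by a margin beyond the usual scatter. For the measured compounds named here, no single-point step between the two measured compounds has been worked out, so their relation is told only by the two values themselves.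

Compound 3, `COC(=O)C1=C(C)NC(=O)N(C(=O)NCCCN2CCN(c3cccc([N+](=O)[O-])c3)CC2)C1c1ccc(F)c(F)c1`, has not yet been measured in this assay. It differs from compound 2 in one place: 3-nitrophenyl in place of 2-ethoxyphenyl on an amine nitrogen in a ring. The aryl group on the ring nitrogen is the one point of variation in this small set, and the two measured values show that changing it can move the number by more than the scatter.

For compound 3 the number in this assay is expected to rise beyond the scatter, with an estimated step of a 5.7-fold higher number from compound 2 to compound 3 (0.76 log units; beyond the scatter). The estimate for compound 3 is 80 nM, expected to lie between 25 nM and 300 nM.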

Compound 3, inhibition constant: 340 nM
The estimate for compound 3 lay 4.3-fold (0.63 log units) below the measured number, outside the stated range (above it).
By their numbers in this assay, from the lowest: compound 2; then compounds 1 and 3 (each within the scatter of the next).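

In this assay, for the compounds shown here, replacing 2-ethoxyphenyl with 3-nitrophenyl gives a 24-fold higher number from compound 2 to compound 3 (1.39 log units; beyond the scatter) with everything else in the two structures unchanged, so this is the first reading that ties a large change in the number to this one position, the amine nitrogen in the six-membered non-aromatic ring with 2 nitrogen. The two groups match in their counts of heavy atoms, at 9 each, and each holds one six-membered aromatic ring of carbon only, so the step appears between groups of equal heavy-atom count that differ in what the aromatic ring carries and where it carries it. Nothing measured among these compounds accounts for the size of this step.

The change alters the substituent and its place on the aromatic ring together, so a 3-ethoxyphenyl or a 2-nitrophenyl group would be needed to tell those two apart. Also open, going by these compounds, is how an unsubstituted phenyl or a 2-methoxyphenyl group would compare with the 2-ethoxyphenyl of compound 2, and whether the same change would give a similar step on the core of compound 1.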